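Fluoro for Bromo on the Anilide of Compound 3

The source may report more compounds than this note shows. Statements on the series, on what has been measured and on what is new or still open speak of the compounds shown alone.

Compound 1, `CCOC(=O)C1=Cc2ccccc2OC1(OCc1cn(CC(=O)Nc2ccc(OC)cc2)nn1)C(F)(F)F`: in a functional assay on HeLa cells (Homo sapiens) for inhibition, read by MTT assay, with a stated time of 24 h (on this read-out higher numbers stand for weaker inhibition and lower numbers for stronger inhibition), compound 1 gives 31900 nM.
Compound 2, `CCOC(=O)C1=Cc2ccccc2OC1(OCc1cn(-c2ccccc2)nn1)C(F)(F)F`: compound 2 gives > 150000 nM, which is a limit of this assay and not a number.
Compound 3, `CCOC(=O)C1=Cc2ccccc2OC1(OCc1cn(CC(=O)Nc2ccccc2Br)nn1)C(F)(F)F`: compound 3 gives > 150000 nM, likewise a limit of this assay.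

Compound 3 thus stands at the upper edge of what this assay reports; among the three values shown, (the limit of > 150000 nM in this assay, at which 2 of the 3 values shown sit). Among the measured compounds shown here, the steps of an at least 4.7-fold higher number from compound 1 to compound 2 (0.67 log units; beyond the scatter) and an at least 4.7-fold higher number from compound 1 to compound 3 (0.67 log units; beyond the scatter) each lead from the one numbered value to a limit, while a step that the two limits leave unreadable from compound 2 to compound 3.

Compound 4, `CCOC(=O)C1=Cc2ccccc2OC1(OCc1cn(CC(=O)Nc2ccccc2F)nn1)C(F)(F)F`, differs from compound 3 by fluoro in place of bromo on an aromatic carbon. For the measured compounds named here, no measured step exchanges one halogen for another on the ring attached to the amide-type nitrogen, so none bears directly on this change; the only step ending at compound 3, an at least 4.7-fold higher number from compound 1 to compound 3 (0.67 log units; beyond the scatter), leaves it at a limit. Without a measured step to scale it, compound 4 is expected to stay near that limit, an expected a number no higher from compound 3 to compound 4 (the limit leaves the size open). For compound 4 the estimate is 150000 nM, ranging from 40000 nM to 400000 nM.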

Compound 4, half-maximal inhibitory concentration: 49900 nM
The estimate for compound 4 lay 3.0-fold (0.48 log units) above the measured number; the measured number falls inside the stated range.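

In this assay, the halogen on this anilide ring makes a readable difference: with fluoro in place of bromo, on an aromatic carbon ortho to a large group, there is an at least 3.0-fold lower number from compound 3 to compound 4 (0.47 log units; beyond the scatter). The (2-fluorophenyl)carbamoyl)methyl group on the aromatic nitrogen also separates from phenyl, with an at least 3.0-fold lower number from compound 2 to compound 4 (0.47 log units; beyond the scatter). With 2-fluorophenyl in place of 4-methoxyphenyl on the amide-type nitrogen there is a 1.6-fold higher number from compound 1 to compound 4 (0.19 log units; within the scatter), so the 4-methoxyphenyl group is not the only ring here that gives a numbered value.

The compounds shown leave open how chloro or a methyl group would read at this place on the ring. They also leave open whether a carboxylic acid in place of the ethyl ester of the shared core would keep a numbered value.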